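Aryl replacement at the amine-bound carbon in the sulfonamide series

The source may report more compounds than this note shows. Statements on the series, on what has been measured and on what is new or still open speak of the compounds shown alone.

Measured compounds, growth inhibition read in a functional assay on BXPC-3 cells (Homo sapiens) for inhibition, read by MTT assay, with a stated time of 72 h; a higher number here means a weaker inhibitor of growth, a lower number a stronger inhibitor of growth:
compound 1 `O=S(=O)(NCCNCc1ccc(-c2ccccc2)cc1)c1cc(C(F)(F)F)cc(C(F)(F)F)c1`: compound 1 gives 1600 nM
compound 2 `O=S(=O)(NCCCNCC1COc2ccccc2O1)c1cc(C(F)(F)F)cc(C(F)(F)F)c1`: compound 2 gives 1200 nM
compound 3 `CC(C)(C)c1ccc(CNCCNS(=O)(=O)c2cc(C(F)(F)F)cc(C(F)(F)F)c2)cc1`: compound 3 gives 8800 nM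

Compound 2 gives the lowest number of the three; its gap to compound 1 is within the scatter, its gap to compound 3 beyond it. Compound 4 `COc1cccc(CNCCCNS(=O)(=O)c2cc(C(F)(F)F)cc(C(F)(F)F)c2)c1` differs from compound 2 by 3-methoxyphenyl in place of 2,3-dihydro-1,4-benzodioxin-2-yl on a saturated chain carbon bound to an amine nitrogen. Going by the values given here, no measured step covers this exchange on the three-carbon chain. Among the compounds with values here, the only measured step, a 5.5-fold higher number from compound 1 to compound 3 (0.74 log units; beyond the scatter), concerns the aryl end of the shorter chain and shows that a swap there can move the number modestly in either direction. Within the data shown here, with no closer precedent, the step from compound 2 to compound 4 is expected to be small, estimated as a 1.7-fold higher number from compound 2 to compound 4 (0.22 log units; within the scatter). Compound 4 is therefore estimated at 2000 nM, with a range from 700 nM to 6000 nM.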

Compound 4, concentration for 50% growth inhibition: 1700 nM
Compound 4: middle estimate off by 1.2-fold (0.07 log units), on the high side; measured number inside the range.
By their numbers in this assay, from the lowest: compounds 2, 1 and 4 (each within the scatter of the next); then compound 3.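

In this assay, 3-methoxyphenyl in place of 2,3-dihydro-1,4-benzodioxin-2-yl on a saturated chain carbon bound to an amine nitrogen gives a 1.4-fold higher number from compound 2 to compound 4 (0.15 log units; within the scatter). This is the only exchange shown on the three-carbon chain, and removing the six-membered non-aromatic ring leaves the number within the scatter. No evidence at hand explains this result.

No pair shown differs in chain length alone. On these data alone, the effect of a carboxylic acid in place of the methoxy group of compound 4 also remains open.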